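The source may report more compounds than this note shows. Statements on the series, on what has been measured and on what is new or still open speak of the compounds shown alone.

Measured compounds in a functional assay on PC-3 cells (Homo sapiens) for cytotoxicity, read by MTT assay, with a stated time of 48 h; on this read-out higher numbers stand for weaker inhibition and lower numbers for stronger inhibition:
compound 1, `CC[N+](C)(CC)CC(=O)N1N=C(C)CC1c1ccccc1OC`, gives 4170 nM
compound 2, `COc1ccccc1C1CC(C)=NN1C(=O)C[N+]1(C)CCCC1`, gives 11200 nM
compound 3, `O=C(CCl)N1N=C(c2cc3ccccc3oc2=O)CC1c1ccccc1`, gives 2980 nM

Compound 3 holds the lowest of the three numbers; against compound 1 its gap lies within the scatter, and only against compound 2 does the gap reach beyond it. Compound 4, `CCN(CC)C1CCN(CC(=O)N2N=C(c3cc4ccccc4oc3=O)CC2c2ccccc2)CC1`, differs from compound 3 in one place: 4-(diethylamino)piperidin-1-yl in place of chloro on a saturated chain carbon bound to a carbonyl carbon. A single measured step is available for comparison, a 2.7-fold higher number from compound 1 to compound 2 (0.43 log units; beyond the scatter), and it also sits on a saturated chain carbon bound to a carbonyl carbon. There a ring took the place of a chain; here a much larger group takes the place of a single chlorine, so that step speaks to the present one only loosely. For the measured compounds named here, with the one comparable swap giving a modest rise, and nothing here addressing an exchange of chloro for an amine-bearing ring, a modest step in either direction is expected rather than a large one. The estimate for compound 4 is 3500 nM, with a range from 1200 nM to 11000 nM, which is expected to mean a 1.2-fold higher number from compound 3 to compound 4 (0.07 log units; within the scatter).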

Compound 4, half-maximal inhibitory concentration: 26100 nM
Compound 4: the middle estimate sits 7.5-fold (0.87 log units) below what was measured, outside the stated range (above it).
By their numbers in this assay, from the lowest: compounds 3 and 1 (each within the scatter of the next); then compound 2; then compound 4.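

In this assay, 4-(diethylamino)piperidin-1-yl in place of chloro on a saturated chain carbon bound to a carbonyl carbon gives an 8.8-fold higher number from compound 3 to compound 4 (0.94 log units; beyond the scatter) and so moves the read-out towards weaker inhibition. For the compounds shown here, the only earlier step at such a place, a 2.7-fold higher number from compound 1 to compound 2 (0.43 log units; beyond the scatter), exchanged one nitrogen-bearing group for another, so this is the first view of what happens when chloro itself leaves this position. On the core of compound 3, the large amine-bearing ring does not keep the number of the chloro compound.

This single pair leaves open whether the rise goes with the piperidine ring, the diethylamino group or the loss of chloro, and how a smaller amine such as dimethylamino, or a bromo group, would read at this place. Nothing given here bears on why the number rose.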